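Methyl in Place of Acetyl on the Weakest Compound

This account rests on a few compounds, and the source may have more. Where it says the series, first, only, none or still open, it means among the compounds named here.

In a functional assay (brain) with Canis familiaris (Canis lupus familiaris) as the target (a higher number here means a weaker inhibitor, a lower number a stronger inhibitor), compound 3 `CC(=O)N(CC(O)CN1CCN(CCCC(c2ccc(F)cc2)c2ccc(F)cc2)CC1)c1ccccc1` gives 390000 nM, the highest number of the three measured and so the weakest inhibitor among them. Compound 1 `COC(CNc1ccccc1)CN1CCN(CCCC(c2ccc(F)cc2)c2ccc(F)cc2)CC1` gives 15000 nM. Compound 2 `COC(CSc1ccccc1)CN1CCN(CCCC(c2ccc(F)cc2)c2ccc(F)cc2)CC1` gives 20000 nM. The next compound, compound 4 `CN(CC(O)CN1CCN(CCCC(c2ccc(F)cc2)c2ccc(F)cc2)CC1)c1ccccc1`, differs from compound 3 in one place: methyl in place of acetyl on a nitrogen on an aromatic ring. In words, this puts methyl in place of acetyl on a nitrogen on an aromatic ring. For the measured compounds named here, no measured step makes this change. Going by the values given here, the only measured step, a 1.3-fold higher number from compound 1 to compound 2 (0.12 log units; within the scatter), swaps a different group and stays within the scatter, so it bears on this change only indirectly. It does show two compounds without the acetyl at similar values, although they also differ from compound 3 elsewhere. With compound 1 at 15000 nM as the guide, a move toward a lower number in this assay is expected, an estimated 9.8-fold lower number from compound 3 to compound 4 (0.99 log units; beyond the scatter). For compound 4 the expected value is 40000 nM, with an estimated range of 12000 nM to 150000 nM.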

Compound 4, half-maximal inhibitory concentration: 19000 nM
For compound 4 the middle estimate is 2.1-fold (0.32 log units) above the measured one; measured number inside the range.
By their numbers in this assay, from the lowest: compounds 1, 4 and 2 (each within the scatter of the next); then compound 3.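

In this assay, methyl in place of acetyl on a nitrogen on an aromatic ring gives a 21-fold lower number from compound 3 to compound 4 (1.31 log units; beyond the scatter), so this single place can carry a large step, which the earlier comparison could not show. Compound 4 also falls in with the two methoxy compounds, with a 1.1-fold lower number from compound 2 to compound 4 (0.02 log units; within the scatter) and a 1.3-fold higher number from compound 1 to compound 4 (0.10 log units; within the scatter), both within the scatter even though each of these steps replaces a whole side chain on the shared core. Among these four, compound 3, the only one carrying acetyl, stands apart from the other three.

As far as these compounds go, whether an ethyl or a benzoyl on that nitrogen would sit with compound 3 or with compound 4 remains open. Nothing shown here gives the reason for the gap between acetyl and methyl.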